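The source may report more compounds than this note shows. Statements on the series, on what has been measured and on what is new or still open speak of the compounds shown alone.

Compound 1, with the structure `COc1cc(Br)cc2cc(C(=O)NCCCO)c(=N)oc12`, belongs to a small set of three related compounds. In an assay on HEK293 cells for displacement of a labelled ligand from adenosine receptor A2b (Homo sapiens), read by scintillation counting, with a stated time of 30 min, tested at 10 uM (on this read-out higher numbers stand for more inhibition at the one concentration tested (going by the name of the read-out) and lower numbers for less inhibition), compound 1 gives 30%, the highest of the three numbers. Compound 3, with the structure `O=C(NCC(O)CO)c1cc2cccc(O)c2oc1=O`, gives 29% in this assay, a number so close to that of compound 1 that the two cannot be told apart within the usual scatter. Compound 2, with the structure `COCCNC(=O)c1cc2cc(Cl)ccc2oc1=N`, gives 9% in this assay, which lies clearly below compound 1, beyond the scatter.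

Compound 4, with the structure `N=c1oc2ccc(Br)cc2cc1C(=O)NCCCO`, has not yet been measured. It differs from compound 1 in one place: hydrogen in place of methoxy on an aromatic carbon. For the measured compounds named here, no pair of measured compounds isolates this particular change, so its effect is unknown. The expectation for this assay is a step from compound 1 to compound 4 of a number 8 percentage points lower from compound 1 to compound 4 (within the scatter), that is, a modest loss at most, likely within the scatter. Compound 4 is therefore estimated to give 22% in this assay, with a likely range from 5% to 40%.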

Compound 4, a percentage reported as inhibition, at one concentration (the size of the read-out at that concentration, not a potency): 25%
Compound 4: the middle estimate sits 3 percentage points below what was measured, and the stated range covers the measured number.
By their numbers in this assay, from the lowest: compound 2; then compounds 4, 3 and 1 (each within the scatter of the next).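

Placing hydrogen in place of methoxy on this aromatic carbon, ortho to a fused ring, gives a number 5 percentage points lower from compound 1 to compound 4 (within the scatter) in this assay, the first direct reading of this change in the set. Compounds 1 and 4 cannot be told apart here, so on this core the methoxy group is not required for the inhibition seen at the one concentration tested. Nothing at hand explains why the two compounds read alike.

On these data alone, what an amine, a fluoro group or an ethoxy group would give on this same aromatic carbon remains open. Also open, as far as these compounds go, is whether the same change would read alike on a core other than that of compound 1, and whether compounds 1 and 4 would separate in a full potency measurement.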